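Replacing a Methyl With an Indole on the Piperidine Ring

The source may report more compounds than this note shows. Statements on the series, on what has been measured and on what is new or still open speak of the compounds shown alone.

Compound 1 `CC1CCN(CC[C@H]2CCCN2S(=O)(=O)c2ccc3cc[nH]c3c2)CC1` is the strongest binder among three compounds measured in an assay on HEK293 cells for binding affinity to 5-hydroxytryptamine receptor 7 (Homo sapiens), read by radioligand binding (a higher number here means a weaker inhibitor, a lower number a stronger inhibitor), where compound 1 gives 2.4 nM. Compound 2 `CC1CCN(CC[C@H]2CCCN2S(=O)(=O)c2ccc3c(c2)NCC3)CC1` gives 22.9 nM, and compound 3 `CC1CCN(CC[C@H]2CCCN2S(=O)(=O)c2ccc3oc(O)nc3c2)CC1` gives 166 nM; each differs from compound 1 in more than one place, so no single change can be read from them. Compound 4 `O=S(=O)(c1ccc2cc[nH]c2c1)N1CCC[C@@H]1CCN1CCC(c2cc3ccccc3[nH]2)CC1` keeps the core of compound 1 and differs in one respect: 1H-indol-2-yl in place of methyl on a saturated ring carbon. Nothing measured here shows how a change at this place acts, so the expectation rests on the strong binding of compound 1 at 2.4 nM. A modest weakening is expected, a 2.5-fold higher number from compound 1 to compound 4 (0.40 log units; beyond the scatter). Compound 4 is estimated at 6 nM, within a range from 1.5 nM to 25 nM.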

Compound 4, inhibition constant: 6.31 nM
Beside the measured number, compound 4's estimate is 1.1-fold (0.02 log units) below it; the range from low to high includes it.
By their numbers in this assay, from the lowest: compound 1; then compound 4; then compound 2; then compound 3.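

Swapping the single-carbon methyl on this saturated ring carbon for the much larger, two-ring 1H-indol-2-yl gives only a 2.6-fold higher number from compound 1 to compound 4 (0.42 log units; beyond the scatter) in this assay. The position therefore accepts a far larger group, and compound 4 keeps a low number at 6.31 nM. Nothing available explains why the step is this small.

Open, on these data alone, is whether a single phenyl ring, which has no ring nitrogen, would give a similar number at this carbon. An amine or a carboxylic acid here also remains untested among these compounds.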